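Methoxy step on the methylated analog

The source may hold more compounds than are shown below. What is called first, only, known or untested is meant among the compounds shown, and "the series" means these compounds.

Of the compounds shown here, three have been measured in a functional assay on HeLa cells (Homo sapiens) for antiproliferative activity, read by MTT assay, with a stated time of 48 h; a higher number here means a weaker inhibitor of growth, a lower number a stronger inhibitor of growth. Compound 1 `CCOC(=O)c1sc2ccc(NCc3c[nH]cn3)cc2c1NC(=O)c1ccccc1` gives 17900 nM. Compound 2 `CCOC(=O)c1sc2ccc(NCc3c[nH]cn3)cc2c1NC(=O)c1ccc(OC)cc1` gives 12900 nM, and compound 3 `CCOC(=O)c1sc2ccc(NCc3nc[nH]c3C)cc2c1NC(=O)c1ccccc1` gives 23300 nM. Compound 3 shows the highest of the three numbers, but the step of a 1.3-fold higher number from compound 1 to compound 3 (0.11 log units; within the scatter) and the gap to compound 2 both fall within the scatter, so no order among the three can be read from this assay.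

Compound 4 `CCOC(=O)c1sc2ccc(NCc3nc[nH]c3C)cc2c1NC(=O)c1ccc(OC)cc1` is not yet measured. It differs from compound 3 by methoxy in place of hydrogen on an aromatic carbon. Among the measured compounds shown here, one measured step bears directly on this change: a 1.4-fold lower number from compound 1 to compound 2 (0.14 log units; within the scatter), the same exchange carried out on the compound without the methyl. The methyl exchange itself, from compound 1 to compound 3, serves only to anchor compound 3. For the measured compounds named here, the one comparable step lay within the scatter. A step of similar size is therefore expected in this assay, leaning toward a lower number and staying within the scatter, with the expected step being a 1.4-fold lower number from compound 3 to compound 4 (0.14 log units; within the scatter). Compound 4 is estimated at 17000 nM, in the range 8000 nM to 38000 nM.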

Compound 4, concentration for 50% growth inhibition: 8220 nM
The estimate for compound 4 lay 2.1-fold (0.32 log units) above the measured number, within the range that was stated.
By their numbers in this assay, from the lowest: compounds 4, 2, 1 and 3 (each within the scatter of the next, the first and the last beyond it).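

Among the compounds shown here, on the core of compound 3, the change from phenyl to 4-methoxyphenyl gives a 2.8-fold lower number from compound 3 to compound 4 (0.45 log units; beyond the scatter), the only step of this exchange in this assay that passes the scatter. The step on the core of compound 1 stayed within it, yet no dependence of the methoxy step on the methyl can be claimed: the same change on two cores in this assay, a 1.4-fold lower number (0.14 log units; within the scatter) from compound 1 to compound 2 and a 2.8-fold lower number (0.45 log units; beyond the scatter) from compound 3 to compound 4, 2.0-fold (0.31 log units) apart, within the scatter of two such steps. With the methoxy in place, the methyl exchange gives a 1.6-fold lower number from compound 2 to compound 4 (0.20 log units; within the scatter), and it matches the earlier methyl step within the scatter: the same change on two cores in this assay, a 1.3-fold higher number (0.11 log units; within the scatter) from compound 1 to compound 3 and a 1.6-fold lower number (0.20 log units; within the scatter) from compound 2 to compound 4, 2.0-fold (0.31 log units) apart, within the scatter of two such steps.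

The compounds shown carry only hydrogen or methoxy on this carbon, and whether a hydroxyl, a chlorine or a dimethylamino group there would give a similar step remains open. From the compounds shown here alone, the ethyl ester is common to all four compounds, and the effect of a carboxylic acid or an amide in its place is also open.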